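The compounds below may be only part of what the source reports. "The series", "measured", "known", "first", "only" and "open" are said of these compounds alone.

Measured so far in an assay on isolated protein for inhibition of Maltase-glucoamylase (Homo sapiens), with stated times of 15 min and 10 min, tested at 64 uM; a higher number here means more inhibition at the concentration tested (going by the name of the read-out), a lower number less inhibition:
compound 1 `C=CCc1cc(CN(CC(C)C)CC(C)C)c(O)c(-c2cc(CC=C)c(O)c(CN(CC(C)C)CC(C)C)c2)c1` gives 6.2%
compound 2 `C=CCc1cc(-c2ccc(O)c(CC=C)c2)c(O)c(C(c2ccc(OC)cc2)N2CCCCC2)c1` gives 85%
compound 3 `C=CCc1cc(-c2ccc(O)c(CC=C)c2)c(O)c(C(c2ccccc2)N2CCC(C)CC2)c1` gives 25.8%

Compound 2 stands highest of the three numbers. The nearest number, that of compound 3, lies lower by a margin beyond the scatter, and the number of compound 1 lies lower still, also beyond the scatter. Among the measured compounds shown here, compound 2 is thus the one member of the set with strong inhibition at the tested concentration.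

Compound 4 `C=CCc1cc(-c2ccc(O)c(CC=C)c2)c(O)c(C(c2cc(Cl)cc(Cl)c2)N2CCCCC2)c1` has not been measured. It differs from compound 2 in one place: 3,5-dichlorophenyl in place of 4-methoxyphenyl on a saturated chain carbon bound to an amine nitrogen in a ring and an aromatic carbon. For the measured compounds named here, no pair of measured compounds differs in exactly this way, and compounds 1 and 3 differ from compound 2 in more than one place, so the measured numbers give no direct reading of this change on its own.

Going by the values given here, the expectation is a fall in this assay of moderate size, beyond the scatter, because the single high reading in the set is that of compound 2 at 85% while the other two compounds sit far lower. Compound 4 is expected near 55%, within a range from 25% to 85%. The expected step is a number 30 percentage points lower from compound 2 to compound 4 (beyond the scatter), with the uncertainty stated wide.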

Compound 4, a percentage reported as inhibition, at one concentration (the size of the read-out at that concentration, not a potency): 87.7%
The estimate for compound 4 lay 32.7 percentage points below the measured number; measured number above the stated range.
By their numbers in this assay, from the lowest: compound 1; then compound 3; then compounds 2 and 4 (each within the scatter of the next).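

At the saturated chain carbon bound to an amine nitrogen in a ring and an aromatic carbon, putting 3,5-dichlorophenyl in place of 4-methoxyphenyl gives a number 2.7 percentage points higher from compound 2 to compound 4 (within the scatter) in this assay. High inhibition at this position therefore does not depend on the oxygen of the 4-methoxyphenyl group, the one hydrogen-bond acceptor in the group that leaves, and it holds with chlorine on the ring instead. Nothing available explains why the two aryl groups read alike.

Open, going by these compounds, is whether this carbon needs an aromatic ring at all; a cyclohexyl or a pyridine ring there would test that. Also open, on these data alone, is whether a morpholine can stand in place of the ring amine of compound 4; compound 3 differs from it in more than one place and cannot answer this.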